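A few compounds are considered here, and "the series" means these few. Any claim that something is new, unique, unknown or untested is made for them only; others in the source may bear on it.

Measured compounds in the series:
compound 1, `CCCCCCCCCCNCCCN`: 2.82
compound 2, `CCCCCCCCCCNCCN`: 2.71

For the measured compounds named here, in a physicochemical assay for lipophilicity (on this read-out lower numbers stand for lower lipophilicity and higher numbers for higher lipophilicity), compound 1 gives 2.82, the higher of the two numbers so far; the nearest is compound 2, which gives 2.71, and the step of a number 0.11 log units lower from compound 1 to compound 2 (within the scatter) is within the scatter, so the two compounds are not separated on this read-out.

The compound still to be measured is compound 3, `CCCCCCCCCCCCCCNCCCN`. Relative to compound 1 the change is butyl in place of hydrogen on a saturated chain carbon, ten or more bonds along the chain from an amine nitrogen. Going by the values given here, the single measured step, a number 0.11 log units lower from compound 1 to compound 2 (within the scatter), concerns a different place and a different kind of change and was within the scatter; no measured step in this set covers a butyl entering in place of hydrogen far out along the saturated chain. There is therefore no direct guide from the measured pairs, and the size of the step is estimated from the nature of the change alone.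

For compound 3 the step is expected to be a number 1.98 log units higher from compound 1 to compound 3 (beyond the scatter), upward and well beyond the scatter. The estimate for compound 3 in this assay is 4.8, with a range from 4.2 to 5.4.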

Compound 3, partition coefficient: 4.88
For compound 3 the middle estimate is 0.08 log units below the measured one, within the range that was stated.
By their numbers in this assay, from the lowest: compounds 2 and 1 (each within the scatter of the next); then compound 3.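

In this assay, the saturated chain proves to be a place where the read-out moves strongly: butyl in place of hydrogen gives a number 2.06 log units higher from compound 1 to compound 3 (beyond the scatter). For the compounds shown here, the only earlier step, a number 0.11 log units lower from compound 1 to compound 2 (within the scatter), left its two compounds unseparated, so this is the first change that separates two compounds on this assay. The rest of the core of compound 1 is unchanged in this pair, so the step goes with the chain change alone, a difference that can equally be read as methyl to pentyl or ethyl to hexyl. No independent finding is available that bears on why the number moves this far.

From the compounds shown here alone, one butyl gives a single point, so how the step runs with a smaller group such as ethyl, or with a longer chain, at the same place remains open. Also open, going by these compounds, are whether a carboxylic acid or a hydroxyl group at that place would shift the number in the same direction, and whether butyl gives a similar step on compound 2.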